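The source may hold more compounds than are shown below. What is called first, only, known or untested is meant among the compounds shown, and "the series" means these compounds.

Working notes on the shared core. Compound 1 `C=C1C[C@]23C[C@@]1(O)CC[C@@H]2c1cccc(C)c1[C@@H]3Cn1cc(-c2ccc(OC)cc2)nn1` carries a methoxy group on an aromatic carbon; in a functional assay on HL-60 cells (Homo sapiens) for cytotoxicity, read by MTT assay, with a stated time of 4 days (a higher number here means a weaker inhibitor, a lower number a stronger inhibitor), compound 1 gives only a limit, > 20000 nM. Compound 2 `C=C1C[C@]23C[C@@]1(O)CC[C@@H]2c1cccc(C)c1[C@@H]3Cn1cc(-c2ccccc2)nn1` has hydrogen in that place; in this assay compound 2 also gives only a limit, > 20000 nM. The step that the two limits leave unreadable from compound 1 to compound 2 therefore has no readable size. Both values sit at the limit of > 20000 nM in this assay, at which 2 of the 2 values shown sit, so compound 2 stands at the limit and no number is known for it. Compound 3 `C=C1C[C@]23C[C@@]1(O)CC[C@@H]2c1cccc(C)c1[C@@H]3Cn1cc(-c2ccc(F)cc2)nn1` differs from compound 2 by fluoro in place of hydrogen on an aromatic carbon. Among the measured compounds shown here, the single measured step, from compound 1 to compound 2, touches the same aromatic carbon but yields no size, both ends being limits; no measured step of known size bears on fluoro for hydrogen. Compound 3 is expected to give a limit again in this assay, an expected step that the limit leaves unreadable from compound 2 to compound 3 without readable size. For compound 3 the expected value in this assay is 30000 nM, within 12000 nM to 100000 nM.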

Compound 3, half-maximal inhibitory concentration: > 20000 nM
Compound 3: no number, only a limit (the forecaster's own chance of this, stated with the estimate: 85%); the middle value lies beyond the limit too.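

Compound 3 also gives only a limit, > 20000 nM, in this assay, so no step among compound 1, compound 2 and compound 3 can be read: the limit of > 20000 nM in this assay, at which 3 of the 3 values shown sit.

As far as these compounds go, what stays open is whether methoxy, hydrogen and fluoro on that aromatic carbon differ at all in this assay.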